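Fluorophenyl isomers on the shared core: positional swap

The source may report more compounds than this note shows. Statements on the series, on what has been measured and on what is new or still open speak of the compounds shown alone.

Compound 1 `COc1cc(-n2cnc3ccc(-c4ccc(C(C)=O)cc4)cc32)cc(OC)c1OC` gives 1540 nM in a functional assay on MCF7 cells (Homo sapiens) for antiproliferative activity, read by MTT assay, with a stated time of 72 h; on this read-out higher numbers stand for weaker inhibition and lower numbers for stronger inhibition. Compound 2 `COc1cc(-n2cnc3ccc(-c4cccc(F)c4)cc32)cc(OC)c1OC` gives 2350 nM in this assay, the measured step being a 1.5-fold higher number from compound 1 to compound 2 (0.18 log units; within the scatter). Within the data shown here, on the two numbers so far, compound 2 stands at the higher end, with compound 1 as its only neighbour and the gap between them inside the usual scatter, so no order between the two can be claimed.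

Compound 3 `COc1cc(-n2cnc3ccc(-c4ccc(F)cc4)cc32)cc(OC)c1OC` is the next member. Its difference from compound 2 is 4-fluorophenyl in place of 3-fluorophenyl on an aromatic carbon; the two share the same atoms, joined differently. Among the measured compounds shown here, no measured step compares two isomers of one substituent on the shared core, so the only reference is the exchange of whole groups in a 1.5-fold higher number from compound 1 to compound 2 (0.18 log units; within the scatter), which itself stayed inside the scatter. A change that keeps every atom and only rearranges one ring substituent is therefore expected to give no step beyond the scatter, in either direction: the estimated step is a 1.1-fold lower number from compound 2 to compound 3 (0.03 log units; within the scatter). For compound 3 the estimate in this assay is 2200 nM, in the range 1000 nM to 5000 nM.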

Compound 3, half-maximal inhibitory concentration: 1770 nM
Beside the measured number, compound 3's estimate is 1.2-fold (0.09 log units) above it; measured number inside the range.
By their numbers in this assay, from the lowest: compounds 1, 3 and 2 (each within the scatter of the next).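

Among these compounds, the pair compound 2 and compound 3 is the first comparison of two isomers on the shared core: 4-fluorophenyl in place of 3-fluorophenyl gives a 1.3-fold lower number from compound 2 to compound 3 (0.12 log units; within the scatter) in this assay and so does not separate the two isomers at this position. Fluoro in place of acetyl on the same phenyl ring gives a 1.1-fold higher number from compound 1 to compound 3 (0.06 log units; within the scatter) and is the first single-substituent exchange read here, with the acetyl and fluoro compounds likewise not separated. Across the three aryl groups shown, no step leaves the scatter, so this position has so far tolerated these changes without a readable shift in the number, and no data are available to explain that result.

Whether any change at this aromatic carbon can move the number beyond the scatter remains open, as the compounds shown carry only a fluorophenyl or acetylphenyl group there. A carboxylic acid or a dimethylamino group on that phenyl ring, or a longer chain in place of the ring, would test whether this tolerance extends beyond these three compounds.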